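Inversion at one ring carbon of the azidomethyl iminosugar

A few compounds are considered here, and "the series" means these few. Any claim that something is new, unique, unknown or untested is made for them only; others in the source may bear on it.

Working notes on a small set of pyrrolidine-type iminosugars tested in an assay on isolated protein for inhibition of alpha-galactosidase (Coffea arabica), with stated times of 5 min and 20 min, tested at 1 mM; a lower number here means less inhibition, a higher number more inhibition at the concentration tested (going by the name of the read-out). Going by the values given here, compound 1 `[N-]=[N+]=NC[C@H]1NC[C@@H](O)[C@H]1O` is the only member with a reported number: in this assay compound 1 gives 88%. The two other measured compounds carry no number. Compound 2 `O[C@@H]1[C@@H](c2cn(Cc3ccccc3)nn2)NC[C@@H]1O` is reported in this assay as "not active" (no number reported), and compound 3 `O=C(NC[C@@H]1NC[C@@H](O)[C@H]1O)c1ccccc1` is reported in this assay as "not active" (no number reported). Among the compounds with values here, no pair of measured compounds differs in only one place, so no single-step comparison is available within the measured set.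

Compound 4 `[N-]=[N+]=NC[C@@H]1NC[C@@H](O)[C@H]1O` has not yet been measured. Its relation to compound 1 is the two compounds have the same atoms and bonds; at least one stereo element is drawn with a configuration in one of them and without one in the other: 1 of 4 stereo elements differ; a stereocentre at a saturated ring carbon is drawn R in compound 1 and S in compound 4. Nothing else changes; the same atoms and bonds are present in both.

Within the data shown here, no measured step exists to calibrate what an inversion of one ring stereocentre does in this assay. Since compound 1 gives 88%, there is room for compound 4 to fall well below it, and an epimer is expected to read lower rather than higher, with a step beyond the usual scatter. The step expected from compound 1 to compound 4 is a number 43 percentage points lower from compound 1 to compound 4 (beyond the scatter). Compound 4 is estimated at 45%, with a range from 5% to 85%.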

Compound 4, a percentage reported as inhibition, at one concentration (the size of the read-out at that concentration, not a potency): 44%
The estimate for compound 4 lay 1 percentage points above the measured number, and the stated range covers the measured number.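

Inverting a single stereocentre at a saturated ring carbon, with the same atoms and bonds present, gives a number 44 percentage points lower from compound 1 to compound 4 (beyond the scatter) in this assay, and this is the first comparison in the series that changes only one place. The read-out is therefore sensitive to configuration at this ring carbon alone, although the inversion does not remove inhibition at the concentration tested: compound 4 still gives 44%. The record attached to this step concerns how the stereocentre is drawn and offers no measured property that would explain the size of the step: the fact that one of compounds 1 and 4 is drawn with a defined configuration and the other without, at the place where they differ

Both numbers are single-concentration percentages, so the step says nothing about how potency changes between the two epimers, and one inversion does not show how the other ring stereocentres behave. Going by these compounds, it also remains open whether an inversion at this carbon has a similar effect when the azidomethyl group is replaced by an aminomethyl group or a carboxylic acid.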